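Removing the hydroxy from the side chain of compound 2

The source may hold more compounds than are shown below. What is called first, only, known or untested is meant among the compounds shown, and "the series" means these compounds.

Of the compounds shown here, two of a shared core have been measured. Compound 1 `CC1=C(CC[C@H]2[C@]3(C)CC[C@H](O)C(C)(C)O[C@H]3CC[C@@]2(C)O)[C@](C)(C/C=C/C(C)(C)OO)[C@H](O)CC1` and compound 2 `CC1=C(CC[C@H]2[C@]3(C)CC[C@H](O)C(C)(C)O[C@H]3CC[C@@]2(C)O)[C@](C)(C/C=C/C(C)(C)O)[C@H](O)CC1` differ only at the end of the side chain; in a functional assay on MCF7 cells (Homo sapiens) for antiproliferative activity, read by MTT assay, with a stated time of 72 h (on this read-out lower numbers stand for stronger inhibition and higher numbers for weaker inhibition), compound 1 gives 27400 nM, while compound 2 gives 21800 nM. The step of a 1.3-fold lower number from compound 1 to compound 2 (0.10 log units; within the scatter) shows that trading the hydroperoxy for a hydroxy changed nothing beyond the scatter, so compound 2 has the lowest of the two numbers but stands within the scatter of compound 1.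

Compound 3 `CC(C)=CCC[C@@]1(C)C(CC[C@H]2[C@]3(C)CC[C@H](O)C(C)(C)O[C@H]3CC[C@@]2(C)O)=C(C)CC[C@H]1O` goes one step further: 3-methylbut-2-en-1-yl in place of 3-hydroxy-3-methylbut-1-en-1-yl on a saturated chain carbon bound to a saturated ring carbon. Within the data shown here, the only step that bears on it is the one from compound 1 to compound 2, which was within the scatter. The oxygen at the chain end thus seems not to drive the read-out, and no step beyond the scatter is expected for a 1.0-fold higher number from compound 2 to compound 3 (0.00 log units; within the scatter). Compound 3 is therefore estimated at 22000 nM, within 8000 nM to 60000 nM.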

Compound 3, half-maximal inhibitory concentration: > 50000 nM
Compound 3: a limit, no number; the forecaster's own chance of this, stated with the estimate: 10%; middle value at least 2.2-fold (0.35 log units) from the limit.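

In this assay, compound 3 gives a limit and not a number: the limit of > 50000 nM in this assay, at which 1 of the 3 values shown sits.

Even so, this chain on a saturated chain carbon bound to a saturated ring carbon proves sensitive to change, which the earlier swap of hydroperoxy for hydroxy had not shown: an at least 2.2-fold higher number from compound 2 to compound 3 (0.36 log units; beyond the scatter). The second step, an at least 1.8-fold higher number from compound 1 to compound 3 (0.26 log units; that floor lies within the scatter), does not show this by itself, so the evidence for weaker inhibition rests on the step with the hydroxy compound alone.

The 3-methylbut-2-en-1-yl chain both lacks the hydroxy and carries its double bond elsewhere, so the compounds shown do not tell these two differences apart. From the compounds shown here alone, whether an amine or a carboxylic acid at the chain end would restore or improve the antiproliferative read-out also stays open.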